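This account rests on a few compounds, and the source may have more. Where it says the series, first, only, none or still open, it means among the compounds named here.

Measured so far: compound 1 `CN(Cc1ccc2nccn2c1)c1nnc(-c2ccccc2)o1` with 2.4 in a physicochemical assay for lipophilicity, at pH 7.4; on this read-out lower numbers stand for lower lipophilicity and higher numbers for higher lipophilicity; compound 2 `CN(Cc1ccc2nccn2c1)c1nnc(-c2ccc(-c3ccccc3)cc2)o1` with 3.9; compound 3 `Cc1cc(-c2c(C)nn(C)c2C)ccc1-c1nnc(N(C)Cc2ccc3nccn3c2)o1` with 3.7.

Compound 2 differs from compound 1 by phenyl in place of hydrogen on an aromatic carbon, and in this assay that gave a number 1.50 log units higher from compound 1 to compound 2 (beyond the scatter). Compound 3 sits on a different core; how the two cores differ is not broken down here. In this assay compound 3 lies near compound 2 and well above compound 1.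

Compound 4 `Cc1cc(-c2c(C)nn(C)c2C)ccc1-c1nnc(N(C)Cc2ccc3ncc(-c4ccccc4)n3c2)o1` is not yet measured. It differs from compound 3 by phenyl in place of hydrogen on an aromatic carbon. This is the same kind of change as that from compound 1 to compound 2, but not the same: there the phenyl entered on an aromatic carbon of a six-membered aromatic ring of carbon only, para to a large group, whereas here it enters on an aromatic carbon of a five-membered aromatic ring with 2 nitrogen, part of a fused system of two rings, next to the ring nitrogen. From compound 3 to compound 4 a step of a number 1.30 log units higher from compound 3 to compound 4 (beyond the scatter) is expected, resting on the step from compound 1 to compound 2 being a number 1.50 log units higher from compound 1 to compound 2 (beyond the scatter). Compound 4 is therefore estimated at 5, between 4.4 and 5.6.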

Compound 4, distribution coefficient: 5.3
The estimate for compound 4 lay 0.30 log units below the measured number; the range from low to high includes it.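

In this assay phenyl in place of hydrogen on an aromatic carbon gave a number 1.60 log units higher from compound 3 to compound 4 (beyond the scatter) and, on the core of compound 1, the same kind of change gave a number 1.50 log units higher from compound 1 to compound 2 (beyond the scatter) as the earlier step, so both steps run in the same direction and are of similar size. The rise therefore carried over from one core to the other in these two pairs, even though the phenyl in compound 4 sits on an aromatic carbon of a five-membered aromatic ring with 2 nitrogen rather than on a six-membered aromatic ring of carbon only. Core and place differ together between the pairs, so they cannot show what either contributes alone or whether the step would hold on a third core, and nothing measured here explains the size of either step.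

The compounds shown leave open what another group at the same carbon of compound 3, such as a primary amine or a carboxylic acid, would do to the number. They also leave open whether phenyl at that same place on the core of compound 1 would give a step of similar size.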